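Propargyloxy to (4-nitrobenzyl)oxy on the shared core

The source may hold more compounds than are shown below. What is called first, only, known or untested is meant among the compounds shown, and "the series" means these compounds.

Compound 1 `C#CCOc1ccc2c(=O)c(-c3cc(OC)c(OC)cc3OC)coc2c1` carries a propargyloxy group on the shared core. In a functional assay on HUVEC cells (Homo sapiens) for antiproliferative activity, read by MTT assay, with a stated time of 24 h (a higher number here means a weaker inhibitor, a lower number a stronger inhibitor), compound 1 gives only a limit, > 10000 nM. Compound 2 `COc1ccc2c(=O)c(-c3cc(OC)c(OC)cc3OC)coc2c1` likewise gives only a limit in this assay, > 10000 nM. Among the measured compounds shown here, the single measured step, a step that the two limits leave unreadable from compound 1 to compound 2, is thus unreadable, and the evidence reduces to the limit of > 10000 nM in this assay, at which 2 of the 2 values shown sit. Compound 3 `COc1cc(OC)c(-c2coc3cc(OCc4ccc([N+](=O)[O-])cc4)ccc3c2=O)cc1OC` differs from compound 1 by 4-nitrophenyl in place of ethynyl on a saturated chain carbon bound to an oxygen on an aromatic ring. For the measured compounds named here, no measured step bears on this change. Compound 3 is expected to remain near the limit, estimated at 15000 nM within 3000 nM to 60000 nM. The expected step that the limit leaves unreadable from compound 1 to compound 3 cannot be sized against a limit.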

Compound 3, half-maximal inhibitory concentration: > 10000 nM
Compound 3: only a limit was reported (the forecaster's own chance of this, stated with the estimate: 70%); the middle value is on the limit's open side.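

Among the compounds shown here, compound 3, like compound 1 and compound 2, gives only a limit, so no step among them can be read: the limit of > 10000 nM in this assay, at which 3 of the 3 values shown sit. The compounds shown leave open whether any group at this place on the shared core gives a numerical value in this assay.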